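The source may hold more compounds than are shown below. What is called first, only, known or untested is meant among the compounds shown, and "the series" means these compounds.

Measured in an ADME assay on L929 cells (Mus musculus) for cytotoxicity, read by resazurin assay, with a stated time of 96 h; on this read-out higher numbers stand for lower toxicity in this test and lower numbers for higher toxicity in this test:
- compound 1 `Clc1ccc2c(NCCCN3CCCCC3)ccnc2c1` gives 61500 nM
- compound 2 `CCCNc1ccnc2cc(Cl)ccc12` gives 283000 nM

Within the data shown here, of these two compounds, compound 2 stands highest, at 283000 nM in this assay, and compound 1 is its only neighbour. Compound 3 (`Clc1ccc2c(NCCN3CCCCC3)ccnc2c1`) remains to be measured. It carries piperidin-1-yl in place of methyl on a saturated chain carbon, two bonds along the chain from a nitrogen on an aromatic ring.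

Among the measured compounds shown here, only one measured step bears on this change. That step, a 4.6-fold higher number from compound 1 to compound 2 (0.66 log units; beyond the scatter), removes piperidin-1-yl at a carbon three bonds along the chain, so it runs in the opposite direction and at a different place. No measurement shows what the different place does on its own, so the guide is only partial. Read in reverse, it points to a modest drop in this assay of about the same size, beyond the scatter. The expected change is a 4.4-fold lower number from compound 2 to compound 3 (0.64 log units; beyond the scatter) in this estimate. Compound 3 is expected at about 65000 nM, with an estimated range of 28000 nM to 150000 nM.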

Compound 3, half-maximal cytotoxic concentration: 64500 nM
For compound 3 the middle estimate is 1.0-fold (0.00 log units) above the measured one; low and high end bracket the measured number.
By their numbers in this assay, from the lowest: compounds 1 and 3 (each within the scatter of the next); then compound 2.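

In this assay, among these compounds, the step of a 4.4-fold lower number from compound 2 to compound 3 (0.64 log units; beyond the scatter) shows that piperidin-1-yl in place of methyl on a saturated chain carbon, two bonds along the chain from a nitrogen on an aromatic ring, also goes with a modest change beyond the scatter, so the earlier step between compound 1 and compound 2 is no longer the only sign that this group lowers the number. The step of a 1.0-fold higher number from compound 1 to compound 3 (0.02 log units; within the scatter) lies within the scatter, which means that piperidin-1-yl in place of (piperidin-1-yl)methyl at this place gives no measurable separation, and the presence of the piperidin-1-yl group, rather than its exact spacing along these two chains, is what tracks with the lower numbers in these three compounds. No measured evidence bears on the reason for either step.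

As far as these compounds go, whether the change follows the ring or its nitrogen stays open, since cyclohexyl or an open-chain diethylamino group at this place would separate the two. Also open, from the compounds shown here alone, is whether a longer chain carrying piperidin-1-yl would stay within the scatter of compound 1 and compound 3.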